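Pentyl for tert-butyl, carried over to a second core

The source may hold more compounds than are shown below. What is called first, only, known or untested is meant among the compounds shown, and "the series" means these compounds.

Of the compounds shown here, three have numbers so far. Compound 1 `CC(C)(C)NC(=O)NS(=O)(=O)c1cc(C#N)ccc1Oc1ccc(F)cc1` gives 4350 nM in a functional assay on HEK293 cells for antagonist activity at thromboxane A2 receptor (Homo sapiens), read by fluorescence and calcium flux; a higher number here means a weaker inhibitor, a lower number a stronger inhibitor. Compound 2 `CCCCCNC(=O)NS(=O)(=O)c1cc(C#N)ccc1Oc1ccc(F)cc1` carries the change pentyl in place of tert-butyl on an amide-type nitrogen and gives 9430 nM in this assay, which makes the step of a 2.2-fold higher number from compound 1 to compound 2 (0.34 log units; beyond the scatter). Compound 3 `Cc1ccccc1Nc1ccc(C#N)cc1S(=O)(=O)NC(=O)NC(C)(C)C` differs from compound 1 in its core by (2-methylphenyl)amino in place of 4-fluorophenoxy on an aromatic carbon; in this assay compound 3 gives 2750 nM, and the step is a 1.6-fold lower number from compound 1 to compound 3 (0.20 log units; within the scatter), so compound 1 and compound 3 are not separated by this assay.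

Compound 4 `CCCCCNC(=O)NS(=O)(=O)c1cc(C#N)ccc1Nc1ccccc1C` is not yet measured. From compound 3 it differs by pentyl in place of tert-butyl on an amide-type nitrogen. The same change is made from compound 1 to compound 2, and among the compounds shown it occurs twice in all. The words describing the place are the same in both pairs, so this is the same change, here made on the core of compound 3 rather than on the core of compound 1, the two cores differing as already set out between compound 1 and compound 3.

With a single earlier instance, the expectation rests on that instance alone. The expected step is a 2.2-fold higher number from compound 3 to compound 4 (0.34 log units; beyond the scatter), taken from a 2.2-fold higher number from compound 1 to compound 2 (0.34 log units; beyond the scatter). Compound 4 is therefore expected to give about 6000 nM in this assay. The expected range for compound 4 runs from 3000 nM to 12000 nM, allowing for the scatter of this kind of measurement and for the change being carried onto a core where it has not been measured before.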

Compound 4, half-maximal inhibitory concentration: 3190 nM
Compound 4: the middle estimate sits 1.9-fold (0.27 log units) above what was measured; the measured number falls inside the stated range.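

In this assay, pentyl in place of tert-butyl on the core of compound 3 gives a 1.2-fold higher number from compound 3 to compound 4 (0.06 log units; within the scatter), so the two chains are not separated on this core, although the same change on the core of compound 1 gave a step beyond the scatter; even so, the two steps cannot be told apart: the same change on two cores in this assay, a 2.2-fold higher number (0.34 log units; beyond the scatter) from compound 1 to compound 2 and a 1.2-fold higher number (0.06 log units; within the scatter) from compound 3 to compound 4, 1.9-fold (0.27 log units) apart, within the scatter of two such steps

Read the other way, (2-methylphenyl)amino in place of 4-fluorophenoxy gives a 3.0-fold lower number from compound 2 to compound 4 (0.47 log units; beyond the scatter), a step beyond the scatter where the same change between the tert-butyl compounds lay within it, and again the two steps cannot be told apart: the same change on two cores in this assay, a 1.6-fold lower number (0.20 log units; within the scatter) from compound 1 to compound 3 and a 3.0-fold lower number (0.47 log units; beyond the scatter) from compound 2 to compound 4, 1.9-fold (0.27 log units) apart, within the scatter of two such steps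

Within what these four compounds can resolve, the chain change carries from one core to the other without a detectable difference, but two instances of each step do not show that the steps are equal or that the two places act independently across the series.

Going by these compounds, whether the same holds for other groups on the amide-type nitrogen, such as a cyclohexyl ring, a longer chain or a chain ending in a carboxylic acid, stays open. Also open, on these data alone, is whether a third core, for example one carrying a benzylamino group in place of (2-methylphenyl)amino, would follow the same pattern.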